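The compounds below may be only part of what the source reports. "The series", "measured", "known", "first", "only" and "open" are said of these compounds alone.

Measured compounds in this series:
compound 1 `CC(C)(C)OC(=O)N1CCC(c2c[nH]c3c(Nc4ccc(S(C)(=O)=O)cc4F)ncnc23)CC1` — > 1000 nM
compound 2 `CS(=O)(=O)c1ccc2c(c1)CCN2c1ncnc2c(C3CCN(c4ncc(Cl)cn4)CC3)coc12` — 42 nM
compound 3 `CN(c1ccc(S(C)(=O)=O)cc1F)c1ncnc2c(C3CCN(C(=O)OC(C)(C)C)CC3)coc12` — > 1000 nM

Compound 1 stands at the weak end of what has been measured in a functional assay on cells for agonist activity at Glucose-dependent insulinotropic receptor (Homo sapiens), read by a luciferase reporter, with a stated time of 4 h; a lower number here means that less compound is needed, a higher number that more compound is needed for the effect: compound 1 gives only a limit of the assay, > 1000 nM, and no number. Compound 3 likewise gives only a limit in this assay, > 1000 nM. Of the three values shown, two thus sit at the limit of > 1000 nM in this assay, at which 2 of the 3 values shown sit. For the measured compounds named here, compound 2 is the one member of the set with a numerical value in this assay, 42 nM.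

Compound 4 `Cn1cc(C2CCN(C(=O)OC(C)(C)C)CC2)c2ncnc(Nc3ccc(S(C)(=O)=O)cc3F)c21` is the next compound to be measured in this assay. It differs from compound 1 in one place: methyl in place of hydrogen on an aromatic nitrogen. Going by the values given here, no step between two measured compounds is known for this change, so its size in this assay cannot be read from the data; a small step, within the scatter, is expected, with no clear direction. Compound 4 is therefore expected to remain near the limit where compound 1 sits, at about 2000 nM, in the range 500 nM to 10000 nM, which means an expected step that the limit leaves unreadable from compound 1 to compound 4.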

Compound 4, half-maximal effective concentration: > 1000 nM
Compound 4: a limit, no number; the forecaster's own chance of this, stated with the estimate: 70%; the middle value lies beyond the limit too.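

Compound 1 and compound 4 both give only a limit in this assay, not a number, so no step can be read for methyl in place of hydrogen on an aromatic nitrogen: the limit of > 1000 nM in this assay, at which 3 of the 4 values shown sit.

The compounds shown leave open whether this methyl changes the activity at all.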